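Halogen swap on the sulfonamide arm of the series

This account rests on a few compounds, and the source may have more. Where it says the series, first, only, none or still open, it means among the compounds named here.

The series keeps the shared core of compound 1 `CCCCc1cn(C[C@H](O)[C@H]2OC(=O)C(OCc3ccccc3)=C2OCc2ccccc2)nn1` and varies the group attached to it. In a functional assay on SW-620 cells (Homo sapiens) for antiproliferative activity, read by MTT assay, with a stated time of 72 h (on this read-out lower numbers stand for stronger inhibition and higher numbers for weaker inhibition), compound 1 gives 47500 nM. Compound 2 `COc1ccccc1-c1cn(C[C@H](O)[C@H]2OC(=O)C(OCc3ccccc3)=C2OCc2ccccc2)nn1` carries 2-methoxyphenyl in that position; in this assay compound 2 reaches only the assay limit, > 100000 nM, and no number. Compound 3 `O=C1O[C@H]([C@@H](O)Cn2cc(CNS(=O)(=O)c3ccc(F)cc3)nn2)C(OCc2ccccc2)=C1OCc1ccccc1` carries the (((4-fluorophenyl)sulfonyl)amino)methyl arm and in this assay gives 41100 nM, one of the two numbers obtained, with compound 1 within the scatter of it. The measured steps are an at least 2.1-fold higher number from compound 1 to compound 2 (0.32 log units; beyond the scatter), a 1.2-fold lower number from compound 1 to compound 3 (0.06 log units; within the scatter) and an at least 2.4-fold lower number from compound 2 to compound 3 (0.38 log units; beyond the scatter); both steps beyond the scatter involve compound 2, whose value is a limit (the limit of > 100000 nM in this assay, at which 1 of the 3 values shown sits).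

Compound 4 `O=C1O[C@H]([C@@H](O)Cn2cc(CNS(=O)(=O)c3ccc(Cl)cc3)nn2)C(OCc2ccccc2)=C1OCc1ccccc1` differs from compound 3 only in chloro in place of fluoro on an aromatic carbon. Among the measured compounds shown here, none of the measured steps touches this ring; all three exchange the whole group on the shared core, so no step bears directly on the halogen swap, which is a small change at the far end of the arm. For compound 4 the expected step in this assay is a 1.0-fold lower number from compound 3 to compound 4 (0.01 log units; within the scatter), within the scatter. Compound 4 is therefore estimated at 40000 nM, with a range from 20000 nM to 85000 nM.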

Compound 4, half-maximal inhibitory concentration: 18000 nM
Compound 4: the middle estimate sits 2.2-fold (0.35 log units) above what was measured, and the stated range ends above it.
By their numbers in this assay, from the lowest: compound 4; then compounds 3 and 1 (each within the scatter of the next). At a limit, above all of these: compound 2.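

In this assay, chloro in place of fluoro on an aromatic carbon para to a large group gives a 2.3-fold lower number from compound 3 to compound 4 (0.36 log units; beyond the scatter), so a change of 1 heavy atom at the far end of the sulfonamide arm registers in this read-out. The arm also now stands apart from the butyl group of compound 1: compound 3 with fluoro lay within the scatter of compound 1, whereas the chloro arm gives a 2.6-fold lower number from compound 1 to compound 4 (0.42 log units; beyond the scatter). Compound 2 remains at a limit and not at a number, so an at least 5.5-fold lower number from compound 2 to compound 4 (0.74 log units; beyond the scatter) sets only a bound on that step: the limit of > 100000 nM in this assay, at which 1 of the 4 values shown sits.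

Two halogens give two points and no trend, so bromo, methyl or methoxy in place of chloro would be needed to tell whether the step continues or is particular to chloro. Also open, on these data alone, is whether the step from fluoro to chloro carries over to other cell lines, or to a core with something other than the two benzyl groups, such as free hydroxyl groups.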